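A few compounds are considered here, and "the series" means these few. Any claim that something is new, unique, unknown or untested is made for them only; others in the source may bear on it.

Compound 2 `N#Cc1ccc2[nH]c(-c3cccnc3)cc2c1` stands highest of the two measured compounds in an assay on isolated protein for inhibition of Aromatase (Homo sapiens), read by fluorescence, using NADPH, with a stated time of 30 min, tested at 50 uM (a higher number here means more inhibition at the concentration tested (going by the name of the read-out), a lower number less inhibition), where compound 2 gives 93.7%. Among the compounds with values here, its only neighbour, compound 1 `O=[N+]([O-])c1ccc2[nH]c(-c3cccnc3)cc2c1`, gives 27.9% in this assay. Within the data shown here, the single measured step, a number 65.8 percentage points higher from compound 1 to compound 2 (beyond the scatter), swapped one group for another on the same aromatic carbon rather than removing it. Compound 3 `c1cncc(-c2cc3ccccc3[nH]2)c1` differs from compound 2 by hydrogen in place of cyano on an aromatic carbon. Among the measured compounds shown here, no measured step removes this group outright, so the expected step of a number 33.7 percentage points lower from compound 2 to compound 3 (beyond the scatter) is a moderate loss with wide uncertainty. Compound 3 is therefore estimated at 60%, within a range from 25% to 90%.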

Compound 3, a percentage reported as inhibition, at one concentration (the size of the read-out at that concentration, not a potency): 81.6%
Estimate against measurement, compound 3: 21.6 percentage points below, within the range that was stated.
By their numbers in this assay, from the lowest: compound 1; then compound 3; then compound 2.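

Within the data shown here, with hydrogen on this aromatic carbon, the position can be read for the first time against a compound with no group there: in this assay the step is a number 12.1 percentage points lower from compound 2 to compound 3 (beyond the scatter) and so cyano gains only modestly over hydrogen. The step of a number 53.7 percentage points higher from compound 1 to compound 3 (beyond the scatter) places nitro far below hydrogen, so the large gap between nitro and cyano comes mostly from a loss with nitro rather than a gain with cyano. On these data alone, how an amine or a carboxylic acid on this carbon would compare with hydrogen stays open. No measured evidence here accounts for these steps.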